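A few compounds are considered here, and "the series" means these few. Any claim that something is new, unique, unknown or untested is made for them only; others in the source may bear on it.

Of the compounds shown here, three have been measured in a functional assay on CHO-RD-HGA16 cells for agonist activity at Orexin/Hypocretin receptor type 1 (Homo sapiens), read by fluorescence and calcium flux, with a stated time of 30 min; a lower number here means that less compound is needed, a higher number that more compound is needed for the effect. Compound 1 `COc1ccc(-c2cccc(C(=O)N(C)C)c2)cc1S(=O)(=O)Nc1cccc(NCCCNC(=O)c2cccc(C)c2)c1` gives 400 nM, compound 2 `COc1ccc(-c2cccc(C(=O)N(C)C)c2)cc1S(=O)(=O)Nc1cccc(NCC(C)NC(=O)c2cccc(C)c2)c1` gives 666 nM, and compound 3 `COc1ccc(-c2cc(C(=O)N(C)C)ccn2)cc1S(=O)(=O)Nc1cccc(NCCNC(=O)c2cccc(C)c2)c1` gives 1810 nM, the highest of the three numbers. Going by the values given here, the one measured step, a 1.7-fold higher number from compound 1 to compound 2 (0.22 log units; within the scatter), altered the chain and not the ring, so it does not speak to the change considered here. Compound 4 `COc1ccc(-c2cncc(C(=O)N(C)C)c2)cc1S(=O)(=O)Nc1cccc(NCCNC(=O)c2cccc(C)c2)c1` differs from compound 3 in the ring alone: 5-(dimethylcarbamoyl)pyridin-3-yl in place of 4-(dimethylcarbamoyl)pyridin-2-yl on an aromatic carbon. Among the compounds with values here, compound 1 and compound 3 differ in more than one place, so their two values show only that the combined change raised the number. Lacking any measured step of this kind, the estimate is a 1.0-fold lower number from compound 3 to compound 4 (0.00 log units; within the scatter), meaning no change expected beyond the scatter. Compound 4 is therefore expected at 1800 nM, within a range from 600 nM to 5400 nM.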

Compound 4, half-maximal effective concentration: 7530 nM
Compound 4: the middle estimate sits 4.2-fold (0.62 log units) below what was measured; measured number above the stated range.
By their numbers in this assay, from the lowest: compounds 1 and 2 (each within the scatter of the next); then compound 3; then compound 4.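

In this assay the swap of 4-(dimethylcarbamoyl)pyridin-2-yl for 5-(dimethylcarbamoyl)pyridin-3-yl gives a 4.2-fold higher number from compound 3 to compound 4 (0.62 log units; beyond the scatter) even though both groups hold the same atoms. At this aromatic carbon, para to a methoxy group, how those atoms are joined therefore changes the number, which the earlier chain step could not show. Nothing available explains this difference. Still open, on these data alone, is how these two pyridines would behave with the longer chain of compound 1. Also open, as far as these compounds go, is whether a carboxylic acid in place of the dimethylcarbamoyl group would lower or raise the number.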